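From Fluorophenyl to Trifluoromethylphenyl: An Expected Step

The source may hold more compounds than are shown below. What is called first, only, known or untested is meant among the compounds shown, and "the series" means these compounds.

Three compounds share one core and differ only in the aryl group carried on an amide-type nitrogen. Compound 1 `COc1cc2ncnc(NCc3cccc(NC(=O)Nc4ccc(C)cc4)c3)c2cc1OC` gives 34200 nM in a functional assay on MGC-803 cells (Homo sapiens) for antiproliferative activity, read by MTT assay; a higher number here means a weaker inhibitor, a lower number a stronger inhibitor. Compound 2 `COc1ccccc1NC(=O)Nc1cccc(CNc2ncnc3cc(OC)c(OC)cc23)c1` gives 7710 nM in this assay, and compound 3 `COc1cc2ncnc(NCc3cccc(NC(=O)Nc4ccccc4F)c3)c2cc1OC` gives 10300 nM in this assay. Compound 3 therefore stands second highest of the three numbers; the nearest number is that of compound 2 and the furthest that of compound 1, as the steps of a 1.3-fold higher number from compound 2 to compound 3 (0.13 log units; within the scatter) and a 3.3-fold lower number from compound 1 to compound 3 (0.52 log units; beyond the scatter) show. The parallel replacement, a 4.4-fold lower number from compound 1 to compound 2 (0.65 log units; beyond the scatter), is of similar size.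

Compound 4 `COc1cc2ncnc(NCc3cccc(NC(=O)Nc4cccc(C(F)(F)F)c4)c3)c2cc1OC` has not been measured. Its difference from compound 3 is 3-(trifluoromethyl)phenyl in place of 2-fluorophenyl on an amide-type nitrogen. Among the measured compounds shown here, no measured step contains a trifluoromethyl or this placement on the ring. What the measured steps do show is that both departures from 4-methylphenyl, a 4.4-fold lower number from compound 1 to compound 2 (0.65 log units; beyond the scatter) and a 3.3-fold lower number from compound 1 to compound 3 (0.52 log units; beyond the scatter), lowered the number modestly, whereas the exchange of fluoro for methoxy, a 1.3-fold higher number from compound 2 to compound 3 (0.13 log units; within the scatter), stayed within the scatter. For the measured compounds named here, with no step bearing directly on the change, the author expects for compound 4 a step of a 1.1-fold lower number from compound 3 to compound 4 (0.06 log units; within the scatter), likely not beyond the scatter. The estimate for compound 4 in this assay is 9000 nM, within 3000 nM to 30000 nM.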

Compound 4, half-maximal inhibitory concentration: > 50000 nM
Compound 4: only a limit was reported; the forecaster's own chance of this, stated with the estimate: 5%; middle value at least 5.5-fold (0.74 log units) from the limit.
By their numbers in this assay, from the lowest: compounds 2 and 3 (each within the scatter of the next); then compound 1. At a limit, above all of these: compound 4.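

Of the compounds shown, only compound 4 is reported as a limit of the assay rather than as a number: the limit of > 50000 nM in this assay, at which 1 of the 4 values shown sits.

Even so, this position on the amide-type nitrogen proves more sensitive than the earlier compounds suggested: 3-(trifluoromethyl)phenyl in place of 2-fluorophenyl gives an at least 4.8-fold higher number from compound 3 to compound 4 (0.68 log units; beyond the scatter), and in place of 2-methoxyphenyl it gives an at least 6.4-fold higher number from compound 2 to compound 4 (0.81 log units; beyond the scatter), whereas the exchange between those two earlier groups stayed within the scatter. Against 4-methylphenyl the change gives an at least 1.4-fold higher number from compound 1 to compound 4 (0.16 log units; that floor lies within the scatter), and since that floor lies within the scatter, the data do not settle whether 3-(trifluoromethyl)phenyl is worse than 4-methylphenyl, only that it does not share the gain seen with the other two groups.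

The step to compound 4 changes the substituent and its placement on the ring together, so the compounds shown cannot separate the effect of the trifluoromethyl from that of its placement. As far as these compounds go, how the number would respond to a plain phenyl, or to a chloro or a nitrile on this ring, stays open, as does the true value of compound 4.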